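Working notes on a cytotoxicity series, compounds 1 to 4

This account rests on a few compounds, and the source may have more. Where it says the series, first, only, none or still open, it means among the compounds named here.

Measured so far:
compound 1 `O=c1n(Cc2cn(Cc3cc4ccc(Cl)cc4nc3Cl)nn2)cnn1-c1ccccc1`: 869 ug/mL
compound 2 `Cc1cccc2cc(Cn3cc(Cn4cnn(-c5ccccc5)c4=O)nn3)c(Cl)nc12`: 729 ug/mL
compound 3 `O=c1n(Cc2cn(Cc3cc4cc(Cl)ccc4nc3Cl)nn2)cnn1-c1ccccc1`: 459 ug/mL

All three compounds share one core and were tested in an ADME assay on HEK293 cells (Homo sapiens) for cytotoxicity, read by MTT assay; on this read-out higher numbers stand for weaker inhibition and lower numbers for stronger inhibition. Compound 3 has the lowest of the three numbers, but its gap to compound 2 and its gap to compound 1 are both within the usual scatter of this assay, so no order of the three can be read from these values.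

Compound 4 `O=c1n(Cc2cn(Cc3cc4ccccc4nc3Cl)nn2)cnn1-c1ccccc1` has not yet been measured. It differs from compound 3 in one place: hydrogen in place of chloro on an aromatic carbon. Within the data shown here, no measured pair shows this change, so there is no step to lean on. Given how close compounds 1, 2 and 3 sit to one another, the step from compound 3 to compound 4 is expected to be small, in no particular direction, and not beyond the scatter: a 1.3-fold higher number from compound 3 to compound 4 (0.12 log units; within the scatter). Compound 4 is therefore estimated at 600 ug/mL in this assay, within a range of 300 ug/mL to 1200 ug/mL.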

Compound 4, half-maximal inhibitory concentration: 655 ug/mL
Beside the measured number, compound 4's estimate is 1.1-fold (0.04 log units) below it; low and high end bracket the measured number.
By their numbers in this assay, from the lowest: compounds 3, 4, 2 and 1 (each within the scatter of the next).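

Hydrogen in place of chloro on an aromatic carbon now has two readings in this assay: a 1.4-fold higher number from compound 3 to compound 4 (0.15 log units; within the scatter) and a 1.3-fold lower number from compound 1 to compound 4 (0.12 log units; within the scatter) both lie within the scatter, so neither chloro group is shown to matter for this read-out. Hydrogen in place of methyl on an aromatic carbon, a 1.1-fold lower number from compound 2 to compound 4 (0.05 log units; within the scatter), also lies within the scatter, so compound 4, which carries none of these three groups, does not stand apart from compounds 1, 2 and 3. No data on hand explain these small steps or say what lies behind them.

Hydrogen, chloro and methyl are the only groups compared here, so it remains open whether this aromatic carbon tolerates every group equally. An amine or a carboxylic acid in the same place could still give a step beyond the scatter.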